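This account rests on a few compounds, and the source may have more. Where it says the series, first, only, none or still open, it means among the compounds named here.

The shared core of compound 3 `COC(=O)/C(=C\c1ccc(OC(=O)c2ccc(OC)c(OC)c2)cc1)Sc1ccnc2cc(Cl)ccc12` carries a 3,4-dimethoxyphenyl group on a carbonyl carbon. For the measured compounds named here, in a functional assay on Jurkat E6.1 cells (Homo sapiens) for cytotoxicity, read by MTT assay, with a stated time of 24 h (a lower number here means a stronger inhibitor, a higher number a weaker inhibitor), compound 3 gives 8290 nM, the lowest of the three numbers measured so far. Compound 1 `COC(=O)/C(=C\c1ccc(OC(=O)c2cccc(OC)c2)cc1)Sc1ccnc2cc(Cl)ccc12` gives 33300 nM, and compound 2 `COC(=O)/C(=C\c1ccc(OC(=O)c2cc(OC)cc(OC)c2)cc1)Sc1ccnc2cc(Cl)ccc12` gives 28900 nM. Compound 4 `COC(=O)/C(=C\c1ccc(OC(=O)c2cc(OC)c(OC)cc2OC)cc1)Sc1ccnc2cc(Cl)ccc12` differs from compound 3 by methoxy in place of hydrogen on an aromatic carbon. Two measured steps add a methoxy in the same way: a 1.2-fold lower number from compound 1 to compound 2 (0.06 log units; within the scatter), whereas a 4.0-fold lower number from compound 1 to compound 3 (0.60 log units; beyond the scatter). The third, a 3.5-fold lower number from compound 2 to compound 3 (0.54 log units; beyond the scatter), moves a methoxy rather than adding one. Adding a methoxy has therefore helped modestly once and not at all once, so only a small change, if any, is expected in this assay, namely a 1.2-fold lower number from compound 3 to compound 4 (0.07 log units; within the scatter). Compound 4 is expected to give about 7000 nM, between 3000 nM and 20000 nM.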

Compound 4, half-maximal inhibitory concentration: 9650 nM
For compound 4 the middle estimate is 1.4-fold (0.14 log units) below the measured one; the measured number falls inside the stated range.
By their numbers in this assay, from the lowest: compounds 3 and 4 (each within the scatter of the next); then compounds 2 and 1 (each within the scatter of the next).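

In this assay, a methoxy placed ortho to a large group and para to a methoxy group changes little, with a 1.2-fold higher number from compound 3 to compound 4 (0.07 log units; within the scatter). The 2,4,5-trimethoxyphenyl group still stands apart from the two weaker groups, with a 3.0-fold lower number from compound 2 to compound 4 (0.48 log units; beyond the scatter) and with a 3.5-fold lower number from compound 1 to compound 4 (0.54 log units; beyond the scatter). Adding a methoxy has now made no clear difference on two cores, and only the step to compound 3 goes against this: the same change on two cores in this assay, a 1.2-fold lower number (0.06 log units; within the scatter) from compound 1 to compound 2 and a 1.2-fold higher number (0.07 log units; within the scatter) from compound 3 to compound 4, 1.3-fold (0.13 log units) apart, within the scatter of two such steps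

On these data alone, it remains open whether an amine or a carboxylic acid on this aromatic carbon would move the number. As far as these compounds go, a longer chain, such as ethoxy, is equally open.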